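Ring swap on a carbonyl carbon

The source may report more compounds than this note shows. Statements on the series, on what has been measured and on what is new or still open speak of the compounds shown alone.

Three compounds have been measured in a functional assay on the whole organism (blood) with Rattus norvegicus as the target, with stated times of 24 h and 1 h, at a dose of 15 mg/kg by the intraperitoneal route; on this read-out higher numbers stand for a stronger effect at the one dose given and lower numbers for a weaker effect:
Compound 1, `O=C(NC[C@@H]1C[C@@H]2C=C[C@@H]1C2)NS(=O)(=O)N1CCC(CCNC(=O)c2cnsc2)CC1`, gives 14%.
Compound 2, `Cn1cccc(C(=O)NCCC2CCN(S(=O)(=O)NC(=O)NC[C@@H]3C[C@@H]4C=C[C@@H]3C4)CC2)c1=O`, gives 40%.
Compound 3, `O=C(NC1CCCCC1)NS(=O)(=O)N1CCC(CCNC(=O)c2nsc3ccccc23)CC1`, gives 17%.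

Compound 1 has the lowest of the three numbers; compound 3 lies within the scatter of it, while compound 2 stands beyond it. Compound 4, `O=C(NC[C@@H]1C[C@@H]2C=C[C@@H]1C2)NS(=O)(=O)N1CCC(CCNC(=O)c2cccc3c2OCCO3)CC1`, differs from compound 1 in one place: 2,3-dihydro-1,4-benzodioxin-5-yl in place of 1,2-thiazol-4-yl on a carbonyl carbon. For the measured compounds named here, only one measured step touches this carbonyl carbon: because a number 26 percentage points higher from compound 1 to compound 2 (beyond the scatter) rose when a six-membered aromatic ring entered there, a rise is also expected for compound 4, though a smaller and less certain one, as the entering group differs. For compound 4 the expected step is a number 11 percentage points higher from compound 1 to compound 4 (beyond the scatter). The estimate for compound 4 is 25%, with a range from 5% to 50%.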

Compound 4, a percentage reported as activity, at one dose (the size of the read-out at that dose, not a potency): 40%
The estimate for compound 4 lay 15 percentage points below the measured number; low and high end bracket the measured number.
By their numbers in this assay, from the lowest: compounds 1 and 3 (each within the scatter of the next); then compounds 2 and 4 (each within the scatter of the next).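

In this assay the 2,3-dihydro-1,4-benzodioxin-5-yl group on this carbonyl carbon gives a number 26 percentage points higher from compound 1 to compound 4 (beyond the scatter) as well, so the earlier rise no longer rests on a single group. The groups in compound 2 and compound 4 differ in their rings, yet the swap gives no change at the digits printed from compound 2 to compound 4 (within the scatter) here. Nothing available explains why either group raises the number. Still open, from the compounds shown here alone, is whether a plain phenyl ring or a benzoic acid group on this carbonyl carbon would do the same, and whether the rise carries over to the core of compound 3.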